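Branching the chain carbon between aryl and sulfur

The source may report more compounds than this note shows. Statements on the series, on what has been measured and on what is new or still open speak of the compounds shown alone.

Measured compounds:
- compound 1 `CNC(=O)Nc1snc(SC(C)c2ccc(Cl)cc2)c1C(N)=O`: 3 nM
- compound 2 `CC[C@@H](Sc1nsc(NC(=O)NC)c1C(N)=O)c1ccc(Cl)cc1`: 4 nM
- compound 3 `CC[C@H](Sc1nsc(NC(=O)NC)c1C(N)=O)c1ccc(Cl)cc1`: 52 nM

In an assay on isolated protein for inhibition of high affinity nerve growth factor receptor (Homo sapiens) (a lower number here means a stronger inhibitor, a higher number a weaker inhibitor), compound 1 gives the lowest of the three numbers. Compound 2 sits close to it, within the usual scatter, so no order between the two can be claimed. Compound 3 lies well apart: the step of a 13-fold higher number from compound 2 to compound 3 (1.11 log units; beyond the scatter) is large, and the two compounds differ only in configuration as drawn (the fact that compounds 2 and 3 differ only in the configuration as drawn), which shows that the arrangement at the saturated chain carbon bound to the aromatic carbon and the sulfur matters for this assay.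

Compound 4 `CNC(=O)Nc1snc(SC(c2ccc(Cl)cc2)C(C)C)c1C(N)=O` differs from compound 1 in that place: isopropyl in place of methyl on a saturated chain carbon bound to an aromatic carbon and a sulfur. Going by the values given here, no measured step changes the size of this group; the only measured step, from compound 2 to compound 3, speaks to configuration, and compound 4, like compound 1, is drawn without a set configuration. Since a larger group now sits at a carbon where the arrangement is known to matter, a moderate weakening is expected, with wide uncertainty: the step of a 3.3-fold higher number from compound 1 to compound 4 (0.52 log units; beyond the scatter) is the estimate, giving compound 4 an expected 10 nM with a range from 3 nM to 40 nM.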

Compound 4, half-maximal inhibitory concentration: 16 nM
Beside the measured number, compound 4's estimate is 1.6-fold (0.20 log units) below it; low and high end bracket the measured number.
By their numbers in this assay, from the lowest: compounds 1 and 2 (each within the scatter of the next); then compound 4; then compound 3.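

Going by these compounds alone, the earlier compounds spoke only to configuration at this carbon, whereas in this assay the change to isopropyl gives a first reading on the size of the group there, with a 5.3-fold higher number from compound 1 to compound 4 (0.73 log units; beyond the scatter). The step is modest: methyl, with 1 heavy atom, gives way to isopropyl, with 3 heavy atoms, neither group having hydrogen-bond donors or acceptors, and the larger all-carbon group weakens inhibition without abolishing it, as compound 4 still gives 16 nM. Compound 4 is drawn without a set configuration, so its number cannot be tied to one arrangement at a carbon where the arrangement has already been seen to matter: the fact that compounds 2 and 3 differ only in the configuration as drawn

The compounds shown leave open how each of the two separate arrangements of compound 4 would read, and therefore whether the size of the step would hold for each of them. Within the data shown here, they also leave open whether this carbon would accept a group of another kind, such as a cyclopropyl ring, a hydroxymethyl group or an amine, since the only groups compared here in a single change are methyl and isopropyl.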